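A few compounds are considered here, and "the series" means these few. Any claim that something is new, unique, unknown or untested is made for them only; others in the source may bear on it.

The measured compounds, in a functional assay on HepG2 cells (Homo sapiens) for antiproliferative activity, read by MTT assay, with a stated time of 72 h; a lower number here means a stronger inhibitor, a higher number a weaker inhibitor:

compound 1, `COc1ccc(-c2cn(C/C=C3\OC(=O)C(OCc4ccccc4)=C3OCc3ccccc3)nn2)cc1`: > 100000 nM
compound 2, `O=C1O[C@H]([C@@H](O)Cn2cc(-c3cccc(O)c3)nn2)C(OCc2ccccc2)=C1OCc1ccccc1`: 62700 nM
compound 3, `O=C1O/C(=C\Cn2cc(-c3ccc(Br)cc3)nn2)C(OCc2ccccc2)=C1OCc1ccccc1`: > 100000 nM

Compound 2 is the only one of the three that gives a number; the other two values are limits. For compound 1 the value in this assay is a limit of the assay, not a number. For compound 3 the value in this assay is likewise a limit. The step that the two limits leave unreadable from compound 1 to compound 3 therefore cannot be read, since both ends sit at the same limit (the limit of > 100000 nM in this assay, at which 2 of the 3 values shown sit).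

The step now followed goes from compound 2 to compound 4, `O=C1O[C@H]([C@@H](O)Cn2ccnn2)C(OCc2ccccc2)=C1OCc1ccccc1`. The change is hydrogen in place of 3-hydroxyphenyl on an aromatic carbon. For the measured compounds named here, none of the measured steps concerns this position: the only measured pair differing in one place, compound 1 and compound 3, varies a group on the phenyl ring and is unreadable anyway. The expectation for compound 4 therefore rests on compound 2 alone, whose value is 62700 nM. Going by the values given here, with no comparable step in hand, compound 4 is expected to lie near compound 2, with a considerable chance that only a limit is reported. The step of a 1.6-fold higher number from compound 2 to compound 4 (0.20 log units; within the scatter) is the expected one, of uncertain direction. Compound 4 is estimated at 100000 nM, within a range from 30000 nM to 300000 nM.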

Compound 4, half-maximal inhibitory concentration: > 100000 nM
Compound 4 ended at the assay's limit (the forecaster's own chance of this, stated with the estimate: 55%); the middle value sits exactly at the limit.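

In this assay, hydrogen in place of 3-hydroxyphenyl on the aromatic carbon of the five-membered aromatic ring with 3 nitrogen gives an at least 1.5-fold higher number from compound 2 to compound 4 (0.20 log units; that floor lies within the scatter). For the compounds shown here, this is the first readable step at this position, since the earlier pair only varied a group on the phenyl ring and its step could not be read. The value of compound 4, > 100000 nM, is a limit of the assay and not a number. The step is therefore only a floor: taking away the whole 3-hydroxyphenyl group leaves no measurable activity in this assay, yet the floor alone does not separate the change from scatter, and compound 2 has no neighbour at this position that gives a number: the limit of > 100000 nM in this assay, at which 3 of the 4 values shown sit.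

Going by these compounds, how far compound 4 really lies from compound 2 stays open. So does whether a group between these two extremes on that carbon, such as a methyl, an aminomethyl or a phenyl ring carrying a carboxylic acid in place of the hydroxyl, would give a number at all.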